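From methoxymethoxy to methoxy on compound 2

This account rests on a few compounds, and the source may have more. Where it says the series, first, only, none or still open, it means among the compounds named here.

In a functional assay on U-937 cells (Homo sapiens) for cytotoxicity, read by resazurin assay, with a stated time of 72 h (a lower number here means a stronger inhibitor, a higher number a weaker inhibitor), compound 1 (`COCOc1cc(OC)cc(OC)c1C(=O)/C=C/c1ccccc1`) gives 2500 nM and compound 2 (`COCOc1cc(OCOC)c(C(=O)/C=C/c2ccccc2)c(OCOC)c1`) gives 8100 nM as the higher of the two numbers. That gap lies beyond the usual scatter, so compound 2 is the weaker inhibitor of the pair.

Compound 3 (`COCOc1cc(OC)c(C(=O)/C=C/c2ccccc2)c(OCOC)c1`) is reached from compound 2 by a single change, hydrogen in place of methoxy on a saturated chain carbon bound to an oxygen on an aromatic ring with hydrogen in place of methoxy on a saturated chain carbon bound to an oxygen on an aromatic ring. One methoxymethoxy thus becomes methoxy. Among the compounds with values here, no step between measured compounds that differ in one place is available, so the size of this change in this assay has not been seen directly. Within the data shown here, the only guide is compound 1, which also carries methoxy and whose 2500 nM stands below the number of compound 2. A modest move towards a lower number is therefore expected, ending between the two measured values. The estimated move is a 1.8-fold lower number from compound 2 to compound 3 (0.26 log units; within the scatter) and it may not clear the scatter by much. For compound 3 the estimated value is 4500 nM with 2000 nM to 9500 nM as the expected range.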

Compound 3, half-maximal inhibitory concentration: 5900 nM
The estimate for compound 3 lay 1.3-fold (0.12 log units) below the measured number; the range from low to high includes it.
By their numbers in this assay, from the lowest: compound 1; then compounds 3 and 2 (each within the scatter of the next).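

Within the data shown here, the result gives the first direct readings of the exchange between methoxymethoxy and methoxy in this assay. Turning one methoxymethoxy into methoxy gives a 1.4-fold lower number from compound 2 to compound 3 (0.14 log units; within the scatter) and so does not separate that pair, which shows that this single change need not register at all on a core still carrying the other methoxymethoxy groups. Read in the opposite sense, with methoxy becoming methoxymethoxy, the same exchange gives a 2.4-fold higher number from compound 1 to compound 3 (0.37 log units; beyond the scatter) and does clear the scatter, so on these compounds it has no single size, and nothing measured alongside these numbers accounts for that difference.

The compounds shown leave open whether this place on the shared core accepts anything other than these two ether groups, for instance a free hydroxyl, an ethoxy group, a longer chain ending in an amine or a carboxylic acid. They also leave open whether the uneven size of the exchange would persist if a group such as chlorine or trifluoromethyl were added elsewhere on the shared core.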